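The compounds below may be only part of what the source reports. "The series", "measured", "known", "first", "only" and "open" are said of these compounds alone.

For the measured compounds named here, compound 1 `C[C@H](NC(=O)C(=O)Nc1cccnc1N(C)C)C(=O)N[C@@H](CC(=O)O)C(=O)COc1c(F)c(F)cc(F)c1F` gives 27 nM in a functional assay on Jurkat cells (Homo sapiens) (on this read-out lower numbers stand for stronger inhibition and higher numbers for weaker inhibition), the lowest of the two numbers measured so far, while compound 2 `C[C@H](NC(=O)C(=O)NCc1ccc(Cl)cc1Cl)C(=O)N[C@@H](CC(=O)O)C(=O)COc1c(F)c(F)cc(F)c1F` gives 165 nM in this assay. Compound 3 `C[C@H](NC(=O)C(=O)NCc1c(Cl)cccc1Cl)C(=O)N[C@@H](CC(=O)O)C(=O)COc1c(F)c(F)cc(F)c1F` differs from compound 1 by 2,6-dichlorobenzyl in place of 2-(dimethylamino)pyridin-3-yl on an amide-type nitrogen. Going by the values given here, the single measured step that bears on this change is a 6.1-fold higher number from compound 1 to compound 2 (0.79 log units; beyond the scatter), in which 2,4-dichlorobenzyl replaced the same 2-(dimethylamino)pyridin-3-yl on the amide-type nitrogen. A step of comparable size in the same direction is therefore expected, a 5.6-fold higher number from compound 1 to compound 3 (0.74 log units; beyond the scatter). Compound 3 is estimated at 150 nM in this assay, with a range from 50 nM to 450 nM.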

Compound 3, half-maximal inhibitory concentration: 110 nM
The estimate for compound 3 lay 1.4-fold (0.13 log units) above the measured number, within the range that was stated.
By their numbers in this assay, from the lowest: compound 1; then compounds 3 and 2 (each within the scatter of the next).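

In this assay, a second dichlorobenzyl group on the amide-type nitrogen also falls short of 2-(dimethylamino)pyridin-3-yl, with a 4.1-fold higher number from compound 1 to compound 3 (0.61 log units; beyond the scatter), so the shortfall is not confined to 2,4-dichlorobenzyl. The 2,4-dichlorobenzyl and 2,6-dichlorobenzyl groups cannot be told apart here, with a 1.5-fold lower number from compound 2 to compound 3 (0.18 log units; within the scatter). Nothing available explains either step. The compounds shown leave open how a plain benzyl group, an unsubstituted phenyl group or a pyridin-3-yl group lacking the dimethylamino group would compare on this nitrogen.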